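The source may report more compounds than this note shows. Statements on the series, on what has been measured and on what is new or still open speak of the compounds shown alone.

Among the compounds with values here, in an ADME assay on microsomes from liver (Homo sapiens) for metabolic stability (a lower number here means slower removal, a higher number faster removal of the compound), compound 2 `CCCC(Oc1ccc(-n2cc(F)cn2)cc1)c1ccc(C(=O)NCCC(=O)O)cc1` gives 12 mL/min/kg, the only exact number so far. Compound 1 `CCCC(Oc1ccc(-n2cc(C#N)cn2)cc1)c1ccc(C(=O)NCCC(=O)O)cc1` gives < 8 mL/min/kg, which is a limit of the assay and not a number. Within the data shown here, the one measured step, an at least 1.5-fold higher number from compound 1 to compound 2 (0.17 log units; that floor lies within the scatter), is fluoro in place of cyano on an aromatic carbon. It rests on (the limit of < 8 mL/min/kg in this assay, at which 1 of the 2 values shown sits), so it gives only a floor for the size of that change.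

Compound 3 `CCCC(Oc1ccc(-n2cc(C)cn2)cc1)c1ccc(C(=O)NCCC(=O)O)cc1` carries methyl in place of fluoro on an aromatic carbon. This swap has not been measured directly, but it is made on the same aromatic carbon as the measured step. With only the small floor of an at least 1.5-fold higher number from compound 1 to compound 2 (0.17 log units; that floor lies within the scatter) as a guide, no large change is expected in this assay. The expected step, a 1.2-fold higher number from compound 2 to compound 3 (0.07 log units; within the scatter), is slightly upward and stays within the scatter. For compound 3 the estimated clearance is 14 mL/min/kg, with an expected range of 8 mL/min/kg to 26 mL/min/kg.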

Compound 3, clearance in the Homo sapiens assay: 16 mL/min/kg
Estimate against measurement, compound 3: 1.1-fold (0.06 log units) below, within the range that was stated.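

In the Homo sapiens assay the step at this aromatic carbon, a 1.3-fold higher number from compound 2 to compound 3 (0.12 log units; within the scatter), means that 4-fluoro-1H-pyrazol-1-yl and 4-methyl-1H-pyrazol-1-yl cannot be told apart here. In a physicochemical assay for lipophilicity, using the shake flask method, at pH 7.4 (a lower number here means a more polar compound, a higher number a more lipophilic compound), compound 2 gives 2 and compound 3 gives 2.1. In the physicochemical assay the same change gives a number 0.10 log units higher from compound 2 to compound 3 (within the scatter), so the two cannot be told apart there either. Against the nitrile, the step in the Homo sapiens assay, an at least 2.0-fold higher number from compound 1 to compound 3 (0.30 log units; that floor lies within the scatter), is only a floor, so it does not establish a real difference between nitrile and methyl at this position. That floor rests on compound 1, whose value is a limit of the assay and not a number: the limit of < 8 mL/min/kg in the Homo sapiens assay, at which 1 of the 3 values shown sits.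

The compounds shown leave open how an amine, a methoxy group or a longer alkyl chain on this carbon would behave in the Homo sapiens assay. They also leave open how far the nitrile truly lies from the fluoro and methyl groups.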